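Pyrrolidine to Dimethylamino in a Cytotoxic Thiazole Series

This account rests on a few compounds, and the source may have more. Where it says the series, first, only, none or still open, it means among the compounds named here.

Compound 1, `OCc1cc(N2CCCC2)ccc1-c1nc2c(s1)C(O)CCC2`: 32 nM
Compound 2, `CN(C)c1ccc(-c2nc3c(s2)C(O)CNC3)c(CO)c1`: 22 nM
Compound 3, `OCc1cc(N2CCCC2)ccc1-c1nc2c(s1)C(O)CNC2`: 20 nM

These three compounds were tested in a functional assay on MDA-MB-361 cells (Homo sapiens) for cytotoxicity, read by sulforhodamine B assay, with a stated time of 2 days; on this read-out lower numbers stand for stronger inhibition and higher numbers for weaker inhibition. Compounds 2 and 3 share one core, and compound 3 turns into compound 2 by dimethylamino in place of pyrrolidin-1-yl on an aromatic carbon. That change gave a 1.1-fold higher number from compound 3 to compound 2 (0.04 log units; within the scatter), so the two numbers are indistinguishable within the scatter of this measurement. Compound 1 carries a different core; the difference between the two cores is not broken down here. Its value lies within the scatter of both compound 2 and compound 3, so the three compounds cannot be ranked against each other on this read-out.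

Compound 4, `CN(C)c1ccc(-c2nc3c(s2)C(O)CCC3)c(CO)c1`, has not yet been measured. It differs from compound 1 by dimethylamino in place of pyrrolidin-1-yl on an aromatic carbon. The place of this change is described in the same words as for the pair compound 3 to compound 2, so it is the same change made on the other core. Because the earlier change gave a 1.1-fold higher number from compound 3 to compound 2 (0.04 log units; within the scatter), the expected step here is a 1.1-fold higher number from compound 1 to compound 4 (0.04 log units; within the scatter), again within the scatter. Compound 4 is therefore estimated at 35 nM, with a likely range from 18 nM to 70 nM.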

Compound 4, half-maximal inhibitory concentration: 420 nM
Compound 4: the middle estimate sits 12-fold (1.08 log units) below what was measured; the measured number lies above the stated range.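

In this assay, putting dimethylamino in place of pyrrolidin-1-yl on the core of compound 1 gave a 13-fold higher number from compound 1 to compound 4 (1.12 log units; beyond the scatter), a large loss of inhibition, whereas the same change on the core of compound 3 left the number unchanged within the scatter. The effect of this change therefore did not carry from one core to the other, and the two steps clearly differ: the same change on two cores in this assay, a 1.1-fold higher number (0.04 log units; within the scatter) from compound 3 to compound 2 and a 13-fold higher number (1.12 log units; beyond the scatter) from compound 1 to compound 4, 12-fold (1.08 log units) apart, beyond the scatter of two such steps

This shows that, in these two pairs, the outcome of the change depends on the core that carries it, but it does not show why, which part of the core is responsible, or how the change would behave on any third core.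

The compounds shown leave open whether another amine in the same place, such as piperidin-1-yl or diethylamino, would behave like pyrrolidin-1-yl or like dimethylamino on the core of compound 1. They also leave open whether the same gap between the two cores would appear with such a group.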